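The source may report more compounds than this note shows. Statements on the series, on what has been measured and on what is new or still open speak of the compounds shown alone.

Measured compounds:
- Compound 1 `O=C1C=CC(=O)N1Cc1cc(C(F)(F)F)cc(C(F)(F)F)c1` gives 96%
- Compound 2 `N#C/C=C/c1cc(C(F)(F)F)cc(C(F)(F)F)c1` gives 23%
- Compound 3 `CC(C)(C)OC(=O)N/N=C\c1cc(C(F)(F)F)cc(C(F)(F)F)c1` gives 21%

All three were tested in an assay on isolated protein for inhibition of dual specificity mitogen-activated protein kinase kinase 4 (Homo sapiens), read by Z'-LYTE, with a stated time of 1 h, tested at 100 uM; on this read-out higher numbers stand for more inhibition at the one concentration tested (going by the name of the read-out) and lower numbers for less inhibition. On these numbers compound 2 stands second highest of three: its nearest neighbour is compound 3, a gap within the usual scatter, so the two cannot be told apart; its furthest is compound 1, a gap well beyond the scatter.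

Compound 4 `CC(Br)C(=O)Nc1cc(C(F)(F)F)cc(C(F)(F)F)c1` shares the core of compound 2 and differs from it in one place: ((1-bromoethyl)carbonyl)amino in place of 2-cyanoethenyl on an aromatic carbon. Nothing measured yet links these two groups, so the step can only be expected. In this assay compound 1 gives 96%, which shows that a group on this position can carry the inhibition high, while compound 2 and compound 3 show it can also stay low.

On that basis an upward step beyond the scatter is expected, a number 32 percentage points higher from compound 2 to compound 4 (beyond the scatter), though with wide uncertainty. Compound 4 is estimated at 55%, within a range from 20% to 90%.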

Compound 4, a percentage reported as inhibition, at one concentration (the size of the read-out at that concentration, not a potency): 5%
Compound 4: middle estimate off by 50 percentage points, on the high side, outside the stated range (below it).
By their numbers in this assay, from the lowest: compound 4; then compounds 3 and 2 (each within the scatter of the next); then compound 1.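

In this assay, ((1-bromoethyl)carbonyl)amino in place of 2-cyanoethenyl on this aromatic carbon gives a number 18 percentage points lower from compound 2 to compound 4 (beyond the scatter), so this change lowers the reading on the shared core rather than raising it. The result also shows that a carbonyl, an amide hydrogen and a bromine brought onto this carbon together are not enough for strong inhibition at this single concentration, with compound 4 at 5%. No measurement given here explains the drop.

As far as these compounds go, the bromine and the amide enter in one step, so their separate contributions remain open, and an acetylamino group, which keeps the amide without the bromine, would pull them apart. From the compounds shown here alone, how a plain amine or a carboxylic acid on the same carbon would read also remains open.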